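The source may hold more compounds than are shown below. What is called first, only, known or untested is meant among the compounds shown, and "the series" means these compounds.

Compound 1 `O=c1[nH]c(=O)n([C@H]2C[C@@H]3O[PH](O)(O)OC[C@H]3O2)cc1F`: 0.06 ug/mL
Compound 2 `O=c1[nH]c(=O)n([C@H]2C[C@@H]3OP(=O)(OCc4ccccc4)OC[C@H]3O2)cc1I`: > 100 ug/mL

For the measured compounds named here, in a functional assay on L1210 cells (Mus musculus) for antiproliferative activity (on this read-out higher numbers stand for weaker inhibition and lower numbers for stronger inhibition), compound 1 gives 0.06 ug/mL, the only plain number among the two results. For compound 2 the result > 100 ug/mL is a limit of the assay rather than a number, as shown by the limit of > 100 ug/mL in this assay, at which 1 of the 2 values shown sits. Going by the values given here, no measured pair differs in a single place, so no measured step guides the change considered here. Compound 3 `O=c1[nH]c(=O)n([C@H]2C[C@@H]3O[PH](O)(O)OC[C@H]3O2)cc1C(F)(F)F` differs from compound 1 by trifluoromethyl in place of fluoro on an aromatic carbon. For compound 3 the step of a 17-fold higher number from compound 1 to compound 3 (1.22 log units; beyond the scatter) is expected to run toward weaker inhibition, beyond the usual scatter. Compound 3 is estimated at 1 ug/mL, with a range from 0.1 ug/mL to 20 ug/mL.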

Compound 3, concentration for 50% inhibition: 0.116 ug/mL
The estimate for compound 3 lay 8.6-fold (0.94 log units) above the measured number; the measured number falls inside the stated range.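

In this assay, for the compounds shown here, the exchange of trifluoromethyl in place of fluoro on an aromatic carbon gives a 1.9-fold higher number from compound 1 to compound 3 (0.29 log units; within the scatter) and is the first single change that can be read. At this position of the shared core, the two groups therefore cannot be told apart on this read-out, even though trifluoromethyl is the larger group. Nothing measured here bears on the reason for this result. As far as these compounds go, whether an amine, a carboxylic acid or a longer chain at the same position would read the same way stays open.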